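Trimming the side chain on a triazene amide series

This account rests on a few compounds, and the source may have more. Where it says the series, first, only, none or still open, it means among the compounds named here.

Of the compounds shown here, three have been measured in a physicochemical assay for lipophilicity, read by HPLC, in phosphate buffer, measured as octanol-water partition, at pH 7.4; on this read-out higher numbers stand for higher lipophilicity and lower numbers for lower lipophilicity. Within the data shown here, compound 1 `CC(=O)N[C@@H](C)C(=O)N(C)/N=N/c1ccc(Br)cc1` gives 2.8, and compound 2 `CCOC(=O)c1ccc(/N=N/N(C)C(=O)[C@H](C)NC(C)=O)cc1` gives 2.52; the only step between two compounds that differ in one place, a number 0.28 log units lower from compound 1 to compound 2 (within the scatter), lies within the scatter. Compound 3 `CC(=O)N[C@H](C(=O)N(C)/N=N/c1ccc(C#N)cc1)C(C)C` gives 2.18, the lowest of the three numbers: compound 2 stands higher by a gap beyond the scatter, and compound 1 higher still.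

Compound 4 `CC(=O)N[C@@H](C)C(=O)N(C)/N=N/c1ccc(C#N)cc1` differs from compound 3 in one place, (methyl in place of isopropyl on a saturated chain carbon bound to an amide-type nitrogen and a carbonyl carbon). Among the measured compounds shown here, none of the measured steps touches this position; the one step available, from compound 1 to compound 2, exchanges substituents on the aromatic ring and says nothing about the saturated chain carbon. The comparison of compound 1 with compound 3 is no guide either, as those two differ in two places at once.

For the measured compounds named here, with no direct precedent, the expectation rests on the size of the group removed: three carbons leave and one enters. Compound 4 is therefore expected to sit lower in this assay than compound 3, by a step estimated at a number 0.78 log units lower from compound 3 to compound 4 (beyond the scatter), beyond the scatter. The estimated value for compound 4 is 1.4, expected to fall between 0.9 and 1.9.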

Compound 4, partition coefficient: 1.41
Estimate against measurement, compound 4: 0.01 log units below, within the range that was stated.
By their numbers in this assay, from the lowest: compound 4; then compound 3; then compounds 2 and 1 (each within the scatter of the next).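

In this assay, the saturated chain carbon bound to an amide-type nitrogen and a carbonyl carbon now has a measured step of its own: with the cyano group held in common, methyl in place of isopropyl gives (a number 0.77 log units lower from compound 3 to compound 4 (beyond the scatter)). Among these compounds, compound 4 also opens up the aromatic position, where the one earlier step stayed within the scatter: cyano in place of ethoxycarbonyl gives (a number 1.11 log units lower from compound 2 to compound 4 (beyond the scatter)), and cyano in place of bromo gives (a number 1.39 log units lower from compound 1 to compound 4 (beyond the scatter)). Nothing among the available findings accounts for the size of any of these steps.

As far as these compounds go, the chain carbon is described by a single pair, so how the number runs with an ethyl group, a longer chain, a hydroxyl group or an amine in that place remains open. Also open, from the compounds shown here alone, is whether methyl in place of isopropyl gives a step of similar size when bromo or ethoxycarbonyl, rather than cyano, sits on the aromatic carbon.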